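Chain Extension Beyond the Weakest Measured Compound

The source may report more compounds than this note shows. Statements on the series, on what has been measured and on what is new or still open speak of the compounds shown alone.

Compound 3 `Cc1cc(C)nc(N(CCCN(C(C)C)C(C)C)C(=O)N(C)C)c1` gives 0% in a functional assay on the whole organism (stomach) for inhibition, with Canis familiaris (Canis lupus familiaris) as the target, at a dose of 20 mg/kg by the oral route (on this read-out higher numbers stand for a stronger effect at the one dose given and lower numbers for a weaker effect), the lowest of the three numbers measured here, and its steps to both other compounds lie beyond the scatter. Compound 1 `Cc1cc(C)nc(N(CCN(C)C)C(=O)N(C)C)c1` gives 58% in this assay, while compound 2 `CCCN(CCC)CCN(C(=O)N(C)C)c1cc(C)cc(C)n1` gives 22%. The measured steps all run in one direction: a number 36 percentage points lower from compound 1 to compound 2 (beyond the scatter), a number 58 percentage points lower from compound 1 to compound 3 (beyond the scatter) and a number 22 percentage points lower from compound 2 to compound 3 (beyond the scatter). Going by the values given here, each time the amine at the end of the chain was enlarged or moved one bond further from the amide-type nitrogen, the inhibition fell, and no measured compound goes against this.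

Compound 4 `Cc1cc(C)nc(N(CCCCN(C(C)C)C(C)C)C(=O)N(C)C)c1` carries the change ((diisopropylamino)methyl in place of diisopropylamino on a saturated chain carbon, three bonds along the chain from an amide-type nitrogen). The same kind of alteration that produced the three downward steps is applied once more, so a further fall would be the natural expectation, yet compound 3 already stands at the floor of the read-out, so no further fall can be registered. A step of a number 3 percentage points higher from compound 3 to compound 4 (within the scatter) of essentially nothing beyond the scatter is therefore expected. Compound 4 is estimated at 3%, with a range from 0% to 15%.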

Compound 4, a percentage reported as inhibition, in the whole organism at one dose (the size of the read-out at that dose, not a potency): 5%
The estimate for compound 4 lay 2 percentage points below the measured number; low and high end bracket the measured number.
By their numbers in this assay, from the lowest: compounds 3 and 4 (each within the scatter of the next); then compound 2; then compound 1.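

In this assay, placing (diisopropylamino)methyl in place of diisopropylamino on a saturated chain carbon, three bonds along the chain from an amide-type nitrogen, gives a number 5 percentage points higher from compound 3 to compound 4 (within the scatter). Going by these compounds alone, this is the first step that stays within the scatter: the earlier steps all fell beyond it, whereas this change leaves compound 3 and compound 4 indistinguishable, so the read-out gives no sign that this further lengthening of the chain either lowers or recovers the inhibition when the chain ends in diisopropylamino. No measurement is available that would explain this result or any of the earlier steps.

Going by these compounds, with both compounds this close to the bottom of the read-out, the effect of chain length on a more active compound remains open, and a dimethylamino group at the end of the longer chain of compound 4 would address that question directly. Also open is whether a cyclic amine such as piperidine or morpholine at the chain end would behave like the open-chain amines, and how any of these compounds would fare at doses other than the single one given.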